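A few compounds are considered here, and "the series" means these few. Any claim that something is new, unique, unknown or untested is made for them only; others in the source may bear on it.

Measured so far:
compound 1 `O=C(Nc1cccc(-n2cc(-c3ccncc3)c(-c3ccc(Cl)c(O)c3)n2)c1)Nc1cccc(C(F)(F)F)c1` — 1510 nM
compound 2 `COc1cc(-c2nn(-c3cccc(NC(=O)c4cccc(C(F)(F)F)c4)c3)cc2-c2ccncc2)ccc1Cl` — 1550 nM
compound 3 `COc1cc(-c2nn(-c3cccc(NC(=O)Nc4ccc(Cl)c(Cl)c4)c3)cc2-c2ccncc2)ccc1Cl` — 1230 nM

All three numbers come from a functional assay on HCT-15 cells (Homo sapiens) for inhibition, read by sulforhodamine B assay, with a stated time of 48 h; a lower number here means a stronger inhibitor of growth, a higher number a weaker inhibitor of growth. Compound 3 holds the lowest of the three, but its gaps to compound 1 and to compound 2 are both within the scatter, so no order among them can be claimed. Going by the values given here, the one counted step, a 1.3-fold lower number from compound 2 to compound 3 (0.10 log units; within the scatter), is likewise within the scatter.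

Compound 4 `COc1cc(-c2nn(-c3cccc(NC(=O)Nc4cccc(C(F)(F)F)c4)c3)cc2-c2ccncc2)ccc1Cl` differs from compound 3 by 3-(trifluoromethyl)phenyl in place of 3,4-dichlorophenyl on an amide-type nitrogen. Among the compounds with values here, no measured step covers exactly this exchange. Compound 1 carries the same urea with the 3-(trifluoromethyl)phenyl group, with a hydroxyl in place of the methoxy on the other aryl ring, and gives 1510 nM. The amide counterpart of compound 4 is compound 2, which gives 1550 nM. Both sit within the scatter of compound 3. Nothing in the series points to a shift beyond the scatter for the step from compound 3 to compound 4, so a flat step is expected: a 1.2-fold higher number from compound 3 to compound 4 (0.09 log units; within the scatter). Compound 4 is therefore estimated at 1500 nM, within 750 nM to 3000 nM.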

Compound 4, concentration for 50% growth inhibition: 870 nM
Compound 4: the middle estimate sits 1.7-fold (0.24 log units) above what was measured; measured number inside the range.
By their numbers in this assay, from the lowest: compounds 4, 3, 1 and 2 (each within the scatter of the next).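

In this assay, all three exchanges around compound 4 stay within the scatter: the aryl group on the amide-type nitrogen (a 1.4-fold lower number from compound 3 to compound 4 (0.15 log units; within the scatter)), the (3-(trifluoromethyl)phenyl)amino group in place of 3-(trifluoromethyl)phenyl on the carbonyl carbon (a 1.8-fold lower number from compound 2 to compound 4 (0.25 log units; within the scatter)), and methyl in place of hydrogen on the oxygen (a 1.7-fold lower number from compound 1 to compound 4 (0.24 log units; within the scatter)). This position therefore takes 3-(trifluoromethyl)phenyl and 3,4-dichlorophenyl without a readable difference, and with 3-(trifluoromethyl)phenyl held constant, neither the urea-for-amide exchange nor the methoxy-for-hydroxyl exchange moves the number beyond the scatter. No measurement bearing on these results is available to explain them.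

Whether any group on this nitrogen gives a step beyond the scatter remains open, as the compounds shown carry only these two aryl groups there. Also open, as far as these compounds go, is how a non-aromatic group such as a cyclohexyl ring, or an aryl group bearing a carboxylic acid or an amine, would read at this position.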